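Swapping an Aromatic Group for a Short Hydroxyethyl Chain

The compounds below may be only part of what the source reports. "The series", "measured", "known", "first", "only" and "open" are said of these compounds alone.

Compound 1 `CC(C)(C)c1cn(C[C@H](O)[C@H]2OC(=O)C(OCc3ccccc3)=C2OCc2ccccc2)nn1`: 730 nM in a functional assay on MCF7 cells (Homo sapiens) for antiproliferative activity, read by MTT assay, with a stated time of 72 h; a higher number here means a weaker inhibitor, a lower number a stronger inhibitor
Compound 2 `O=C1O[C@H]([C@@H](O)Cn2cc(-c3cc(F)cc(F)c3)nn2)C(OCc2ccccc2)=C1OCc1ccccc1`: 27700 nM in this assay

Among the compounds with values here, compound 2 stands at the higher of the two numbers measured so far, and the single measured step, a 38-fold higher number from compound 1 to compound 2 (1.58 log units; beyond the scatter), is large. Compound 3 `O=C1O[C@H]([C@@H](O)Cn2cc(CCO)nn2)C(OCc2ccccc2)=C1OCc1ccccc1` differs from compound 2 by 2-hydroxyethyl in place of 3,5-difluorophenyl on an aromatic carbon. That step shows this position can shift the read-out strongly, and compound 1 with its small non-ring group gave the lower number, so a move back toward a smaller group is expected to lower the number for compound 3, a 9.2-fold lower number from compound 2 to compound 3 (0.97 log units; beyond the scatter), though with wide uncertainty. Compound 3 is estimated at 3000 nM, within a range of 700 nM to 15000 nM.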

Compound 3, half-maximal inhibitory concentration: 63400 nM
Compound 3: middle estimate off by 21-fold (1.32 log units), on the low side, and the stated range ends below it.
By their numbers in this assay, from the lowest: compound 1; then compound 2; then compound 3.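

Replacing the aromatic ring with a short chain did not lower the number in this assay: it gave a 2.3-fold higher number from compound 2 to compound 3 (0.36 log units; beyond the scatter) and also an 87-fold higher number from compound 1 to compound 3 (1.94 log units; beyond the scatter) when set against tert-butyl. Having no ring is therefore not enough for a low number at this aromatic carbon, since tert-butyl and 2-hydroxyethyl both lack a ring yet lie far apart. Nothing available explains this gap.

Still open, from the compounds shown here alone, is whether a plain propyl chain, a cyclopropyl ring or an amine here would fall nearer compound 1.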